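The source may report more compounds than this note shows. Statements on the series, on what has been measured and on what is new or still open speak of the compounds shown alone.

Compound 1 `CCOc1ccc(CCCN2CC=C(CCC(=O)NO)C2=O)cc1`: 2210 nM
Compound 2 `O=C(CCC1=CCN(Cc2ccc(Cl)cc2)C1=O)NO`: 1990 nM
Compound 3 `N#Cc1cccc(CN2CC=C(CCC(=O)NO)C2=O)c1`: 3600 nM

In a functional assay on MDA-MB-231 cells (Homo sapiens) for inhibition, read by sulforhodamine B assay (a higher number here means a weaker inhibitor of growth, a lower number a stronger inhibitor of growth), compound 1 gives 2210 nM. Compound 2 gives 1990 nM and compound 3 gives 3600 nM in this assay; neither number is separated from that of compound 1 by more than the usual scatter, so the three compounds sit at one level of growth inhibition. Compound 4 `Cc1ccc(CCCN2CC=C(CCC(=O)NO)C2=O)cc1` has not been measured yet. It differs from compound 1 in one place: methyl in place of ethoxy on an aromatic carbon The rest of the molecule is unchanged. For the measured compounds named here, no pair of measured compounds isolates a change of this kind, so the expected step in this assay is small, most likely none beyond the scatter. Compound 4 is therefore expected to give about 2500 nM, within a range from 1000 nM to 6000 nM, corresponding to a 1.1-fold higher number from compound 1 to compound 4 (0.05 log units; within the scatter), a step expected to stay within the scatter.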

Compound 4, concentration for 50% growth inhibition: 2210 nM
For compound 4 the middle estimate is 1.1-fold (0.05 log units) above the measured one; low and high end bracket the measured number.
By their numbers in this assay, from the lowest: compounds 2, 1, 4 and 3 (each within the scatter of the next).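

This gives the series its first comparison of compounds that differ in one place. On an aromatic carbon para to a large group, methyl in place of ethoxy gives no change at the digits printed from compound 1 to compound 4 (within the scatter) in this assay and growth inhibition stays at one level with or without the ethoxy oxygen. No independent measurement is available to explain this result.

On these data alone, whether an amine, a carboxylic acid or a longer alkoxy chain at this position would move the number beyond the scatter remains open. So does the effect of plain hydrogen there.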